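This account rests on a few compounds, and the source may have more. Where it says the series, first, only, none or still open, it means among the compounds named here.

The series shares one core, varied at the long chain on the core and at the acid-bearing side chain. For the measured compounds named here, compound 1 `C[C@H](CC(=O)O)CC(=O)c1c(CCCCCCc2ccccc2)n(C)c2ccc(Cl)cc12` carries the phenyl-terminated chain and a stereocentre drawn S; in a functional assay for antagonist activity at Oxoeicosanoid receptor 1 (Homo sapiens), read by fluorescence and calcium flux, with stated times of 2 min and 1 min (a higher number here means a weaker inhibitor, a lower number a stronger inhibitor), compound 1 gives 0.12 nM, the lowest number so far, and its gaps to compound 2 and to compound 3 lie beyond the scatter. Compound 2 `CC(CC(=O)O)CC(=O)c1c(CCCCc2ccccc2)n(C)c2ccc(Cl)cc12`, with a shorter chain and no drawn configuration, gives 38 nM in this assay. Compound 3 `CC(CC(=O)O)CC(=O)c1c(CCCCCC(F)(F)F)n(C)c2ccc(Cl)cc12` gives 38 nM in this assay; the step of no change at the digits printed from compound 2 to compound 3 (within the scatter) shows that exchanging phenyl for 2,2,2-trifluoroethyl on the chain carbon four bonds along the chain from an aromatic carbon stays within the scatter.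

Compound 4 `C[C@@H](CC(=O)O)CC(=O)c1c(CCCCCCc2ccccc2)n(C)c2ccc(Cl)cc12` is the configurational partner of compound 1: the two compounds have the same atoms and bonds and differ only in configuration as drawn: 1 of 1 stereo elements differ; a stereocentre at a saturated chain carbon is drawn S in compound 1 and R in compound 4. Going by the values given here, none of the measured steps inverts a stereocentre, and compound 2 and compound 3 are drawn without configuration, so no measured step sets the size of this one. Only a general expectation remains, that the other drawn configuration of the strongest compound is weaker. In this assay compound 4 is therefore expected to give 15 nM, within 1.5 nM to 200 nM. The expected step of a 130-fold higher number from compound 1 to compound 4 (2.10 log units; beyond the scatter) is a loss carrying wide uncertainty.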

Compound 4, half-maximal inhibitory concentration: 23 nM
Compound 4: middle estimate off by 1.5-fold (0.19 log units), on the low side; the range from low to high includes it.
By their numbers in this assay, from the lowest: compound 1; then compounds 4, 2 and 3 (each within the scatter of the next).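

Inverting the stereocentre at the saturated chain carbon from S to R gives, in this assay, a 190-fold higher number from compound 1 to compound 4 (2.28 log units; beyond the scatter), the first measured step at this position. The whole step belongs to this one stereocentre, because nothing else separates the pair: the fact that compounds 1 and 4 differ only in the configuration as drawn. With the chain and the rest of the core held constant, configuration at this carbon is thus a large determinant of the number on its own, which compound 2 and compound 3, both drawn without configuration, could not show.

As far as these compounds go, whether the S form also gives the lower number with the shorter chain of compound 2 or the fluorinated chain of compound 3 remains open. Also open, from the compounds shown here alone, is whether an ethyl group in place of the methyl group at this stereocentre keeps a gap of this size.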